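The source may report more compounds than this note shows. Statements on the series, on what has been measured and on what is new or still open speak of the compounds shown alone.

Compound 1 `COc1cc(/C=C/C(=O)/C=C/c2ccco2)ccc1OCc1cn(CCCOc2cc(=O)oc3ccccc23)nn1` gives 59%
Compound 2 `COc1ccccc1/C=C/C(=O)/C=C/c1ccc(OCc2cn(CCCOc3cc(=O)oc4ccccc34)nn2)c(OC)c1` gives 57%

These numbers come from a functional assay on COLO 205 cells (Homo sapiens) for inhibition, read by sulforhodamine B assay, with a stated time of 48 h, tested at 50 uM (a higher number here means more inhibition of growth at the concentration tested, a lower number less inhibition of growth), and lie within the scatter of each other, so compound 2 cannot be ranked against compound 1. Compound 3 `COc1cccc(/C=C/C(=O)/C=C/c2ccc(OCc3cn(CCCOc4cc(=O)oc5ccccc45)nn3)c(OC)c2)c1` has not yet been measured and has the same atoms as compound 2, joined differently: 3-methoxyphenyl in place of 2-methoxyphenyl on a double-bonded chain carbon bound to a double-bonded chain carbon is the whole change, with 3-methoxyphenyl in place of 2-methoxyphenyl on a double-bonded chain carbon bound to a double-bonded chain carbon. Among the measured compounds shown here, the only measured step at this place, furan-2-yl replaced by 2-methoxyphenyl, is a number 2 percentage points lower from compound 1 to compound 2 (within the scatter) and so stays small. For the measured compounds named here, no measured step shifts a methoxy group itself, so the evidence is thin, but no step beyond the scatter is expected in this assay here. An estimated a number 1 percentage points higher from compound 2 to compound 3 (within the scatter) is expected. For compound 3 the expected value is 58% (estimated range 46% to 70%).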

Compound 3, percent growth inhibition at one concentration: 52%
Compound 3: the middle estimate sits 6 percentage points above what was measured; the range from low to high includes it.
By their numbers in this assay, from the lowest: compounds 3, 2 and 1 (each within the scatter of the next).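

In this assay, among the compounds shown here, putting 3-methoxyphenyl in place of 2-methoxyphenyl on a double-bonded chain carbon bound to a double-bonded chain carbon gives a number 5 percentage points lower from compound 2 to compound 3 (within the scatter) and is the first measured step that shifts the methoxy group itself, yet it does not separate the two compounds. Putting 3-methoxyphenyl in place of furan-2-yl gives a number 7 percentage points lower from compound 1 to compound 3 (within the scatter), so none of the three groups seen at this place can be ranked against another in this assay. No measurement is available that would explain these small differences.

As far as these compounds go, it remains open whether a different kind of group at this place, such as a phenyl ring carrying an amine or a carboxylic acid, would give a step beyond the scatter. The effect of 4-methoxyphenyl there is also unknown.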